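A few compounds are considered here, and "the series" means these few. Any claim that something is new, unique, unknown or untested is made for them only; others in the source may bear on it.

Compound 1 `Cc1ccc(S(=O)(=O)Oc2ccc3c(c2C)[C@H](Cn2cc(-c4ccccn4)nn2)[C@@]24CC(=O)[C@@](C)(CC[C@@H]32)C4)cc1` was examined in a functional assay on SW480 cells (Homo sapiens) for cytotoxicity, read by MTT assay, with a stated time of 4 days; on this read-out higher numbers stand for weaker inhibition and lower numbers for stronger inhibition. In that test compound 1 gives only a limit, > 20000 nM. Compound 3 `Cc1c(O)ccc2c1[C@H](Cn1cc(-c3ccccn3)nn1)[C@@]13CC(=O)[C@@](C)(CC[C@@H]21)C3` shares the core, with hydrogen in place of (4-methylphenyl)sulfonyl on an oxygen on an aromatic ring; in this assay compound 3 also gives only a limit, > 20000 nM. The step that the two limits leave unreadable from compound 1 to compound 3 is therefore of unreadable size. Compound 2 `C=C1C(=O)[C@]23C[C@@]1(O)CC[C@H]2c1ccc(O)c(C)c1[C@@H]3Cn1cc(-c2ccccn2)nn1` has a different core and in this assay compound 2 gives 410 nM. Compound 4 `Cc1ccc(S(=O)(=O)Oc2ccc3c(c2C)[C@H](Cn2cc(-c4ccc(C(F)(F)F)cc4)nn2)[C@@]24CC(=O)[C@@](C)(CC[C@@H]32)C4)cc1` carries 4-(trifluoromethyl)phenyl in place of pyridin-2-yl on an aromatic carbon. For the measured compounds named here, no measured step covers this change, and compound 1 itself sits at the limit of > 20000 nM in this assay, at which 2 of the 3 values shown sit. For compound 4 the estimate is 30000 nM, within 8000 nM to 100000 nM, most probably again only a limit. That estimate means a step that the limit leaves unreadable from compound 1 to compound 4, expected to stay within the scatter.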

Compound 4, half-maximal inhibitory concentration: > 20000 nM
Compound 4 was reported as a limit (the forecaster's own chance of this, stated with the estimate: 85%); the middle value does not contradict the limit.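

Compound 1 and compound 4 are both reported only as limits, so no step between them can be read: the limit of > 20000 nM in this assay, at which 3 of the 4 values shown sit.

On these data alone, whether 4-(trifluoromethyl)phenyl in place of pyridin-2-yl makes any difference at all stays open.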